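Semicarbazone anilinoquinazolines: HepG2 cytotoxicity notes

A few compounds are considered here, and "the series" means these few. Any claim that something is new, unique, unknown or untested is made for them only; others in the source may bear on it.

Measured compounds:
compound 1 `O=C(N/N=C/c1ccc([N+](=O)[O-])cc1)Nc1cc2c(Nc3ccc(F)c(Cl)c3)ncnc2cc1O[C@H]1CCOC1` — 35300 nM
compound 2 `O=C(N/N=C/c1ccc(F)cc1Cl)Nc1cc2c(Nc3ccc(F)c(Cl)c3)ncnc2cc1O[C@H]1CCOC1` — 26100 nM
compound 3 `COc1cc2ncnc(Nc3ccc(F)c(Cl)c3)c2cc1NC(=O)N/N=C/c1ccc([N+](=O)[O-])cc1` — 34100 nM

All three numbers come from a functional assay on HepG2 cells (Homo sapiens) for cytotoxicity, read by MTT assay, with a stated time of 72 h; on this read-out lower numbers stand for stronger inhibition and higher numbers for weaker inhibition. In this assay compound 1 gives 35300 nM and compound 2 gives 26100 nM; the step between them is a 1.4-fold lower number from compound 1 to compound 2 (0.13 log units; within the scatter). The structural change behind that step is 2-chloro-4-fluorophenyl in place of 4-nitrophenyl on a carbon with a double bond to nitrogen. Compound 3 gives 34100 nM in this assay, and its step from compound 1 is a 1.0-fold lower number from compound 1 to compound 3 (0.02 log units; within the scatter), carried by methyl in place of oxolan-3-yl on an oxygen on an aromatic ring. Among the compounds with values here, no step between compound 2 and compound 3 is broken down here; their two values lie close to one another.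

Compound 4 `COc1cc2ncnc(Nc3ccc(F)c(Cl)c3)c2cc1NC(=O)N/N=C/c1ccc(F)cc1Cl` has not yet been measured. Within the data shown here, it is related to compound 3 by 2-chloro-4-fluorophenyl in place of 4-nitrophenyl on a carbon with a double bond to nitrogen, which is the same change as the one from compound 1 to compound 2: the place is described in the same words in both cases, and the two cores differ only by the change already given as methyl in place of oxolan-3-yl on an oxygen on an aromatic ring. The first occurrence of this change gave a step within the scatter, and the change of core from compound 1 to compound 3 also gave a step within the scatter. On that basis the step from compound 3 to compound 4 is expected to be a 1.3-fold lower number from compound 3 to compound 4 (0.12 log units; within the scatter), small and not separable from repeat variation. Compound 4 is therefore estimated to give 26000 nM in this assay, with a plausible range from 12000 nM to 60000 nM.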

Compound 4, half-maximal inhibitory concentration: 29200 nM
For compound 4 the middle estimate is 1.1-fold (0.05 log units) below the measured one; measured number inside the range.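

In this assay, 2-chloro-4-fluorophenyl in place of 4-nitrophenyl on a carbon with a double bond to nitrogen gives a 1.2-fold lower number from compound 3 to compound 4 (0.07 log units; within the scatter), and this change reads the same on both cores: the same change on two cores in this assay, a 1.4-fold lower number (0.13 log units; within the scatter) from compound 1 to compound 2 and a 1.2-fold lower number (0.07 log units; within the scatter) from compound 3 to compound 4, 1.2-fold (0.06 log units) apart, within the scatter of two such steps. Methyl in place of oxolan-3-yl on an oxygen on an aromatic ring, now read with 2-chloro-4-fluorophenyl in the molecule, gives a 1.1-fold higher number from compound 2 to compound 4 (0.05 log units; within the scatter), and it also reads the same in both settings: the same change on two cores in this assay, a 1.0-fold lower number (0.02 log units; within the scatter) from compound 1 to compound 3 and a 1.1-fold higher number (0.05 log units; within the scatter) from compound 2 to compound 4, 1.2-fold (0.06 log units) apart, within the scatter of two such steps. The four compounds thus show that neither change moves the number measurably on these cores, but they do not show that an effect of real size would carry from one core to another, as every step here is within the scatter and so offers no strict test of transfer.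

Going by these compounds, it remains open whether any group on the carbon with a double bond to nitrogen can move the number beyond the scatter, for example a phenyl bearing an amine or a carboxylic acid in place of the two substituted phenyl groups seen here. The same question stands on the oxygen on the aromatic ring, where a longer chain ending in an amine could be read against methyl and oxolan-3-yl.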